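Replacing the pyridin-2-yl group of compound 1

This account rests on a few compounds, and the source may have more. Where it says the series, first, only, none or still open, it means among the compounds named here.

Measured values in a functional assay on KBVIN cells (Homo sapiens) for antiproliferative activity, read by sulforhodamine B assay, with a stated time of 3 days; on this read-out lower numbers stand for stronger inhibition of growth and higher numbers for weaker inhibition of growth:
compound 1 `O=C(Nc1ccccn1)c1cccc(Nc2ncc(F)c(Nc3ccc(F)cc3)n2)c1`: 13700 nM
compound 2 `O=C(Nc1cccc(Nc2ncc(F)c(Nc3ccc(F)cc3)n2)c1)c1ccncc1`: 4570 nM
compound 3 `O=C(Nc1cccc(Nc2ncc(F)c(Nc3ccc(F)cc3)n2)c1)c1ccccc1`: > 10000 nM (a limit)

Compound 1 has the higher of the two actual numbers, and compound 2 is its nearest neighbour. Compound 3 gives only a limit, not a number.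

Compound 4 `COc1cc(NC(=O)c2cccc(Nc3ncc(F)c(Nc4ccc(F)cc4)n3)c2)cc(OC)c1` keeps the core of compound 1, with 3,5-dimethoxyphenyl in place of pyridin-2-yl on an amide-type nitrogen.

Within the data shown here, no measured step makes this exact change, so the evidence is indirect. The steps closest to it are a 3.0-fold lower number from compound 1 to compound 2 (0.48 log units; beyond the scatter) and an at least 2.1-fold higher number from compound 2 to compound 3 (0.34 log units; beyond the scatter). The remaining step, a step that the limit leaves unreadable from compound 1 to compound 3, has no readable size. Among the measured compounds shown here, the one step with two actual numbers, a 3.0-fold lower number from compound 1 to compound 2 (0.48 log units; beyond the scatter), is modest, and compound 3 offers no sign of a gain with a carbon-only ring. No step beyond the scatter is therefore expected in this assay, and a report as a limit remains possible. The expected change is a 1.5-fold lower number from compound 1 to compound 4 (0.18 log units; within the scatter). For compound 4 the estimated value is 9000 nM, with an expected range from 3000 nM to 25000 nM.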

Compound 4, concentration for 50% growth inhibition: 12700 nM
For compound 4 the middle estimate is 1.4-fold (0.15 log units) below the measured one; the measured number falls inside the stated range.
By their numbers in this assay, from the lowest: compound 2; then compounds 4 and 1 (each within the scatter of the next).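

In this assay, 3,5-dimethoxyphenyl in place of pyridin-2-yl on the amide-type nitrogen gives a 1.1-fold lower number from compound 1 to compound 4 (0.03 log units; within the scatter), a step that shows no change. Among these compounds, compound 4 therefore provides the first actual number for a carbon-only ring at this place, and the ring nitrogen of pyridin-2-yl is not needed to hold the value at the level of compound 1. Across this pair, the entering group's two methoxy groups and carbon-only ring leave growth inhibition unmoved, so this exchange offers no gain in this read-out.

The step from compound 1 to compound 3 cannot be read. Still open, going by these compounds, is whether a carboxylic acid, a dimethylamino group or a single methoxy group on the ring at this place would shift the number in this assay.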